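Piperidine Replaces Isoindoline on a Nitro Sulfone Amide

The source may hold more compounds than are shown below. What is called first, only, known or untested is meant among the compounds shown, and "the series" means these compounds.

Of the compounds shown here, three have been tested in an assay on isolated protein for inhibition of thyroid hormone receptor beta (Homo sapiens), read by fluorescence polarization; a lower number here means a stronger inhibitor, a higher number a weaker inhibitor. Compound 1 `CS(=O)(=O)c1ccc(C(=O)NCCCC(=O)N2Cc3ccccc3C2)cc1[N+](=O)[O-]` gives only a limit there, > 60000 nM. Compound 2 `CCCN(C(=O)CN(C)C(=O)c1ccc(S(C)(=O)=O)c([N+](=O)[O-])c1)c1ccccc1` also gives only a limit, > 60000 nM. Compound 3 `CS(=O)(=O)c1ccc(C(=O)NCC(=O)N2CCc3ccccc3C2)cc1[N+](=O)[O-]` gives a measured value of 46000 nM. Compound 1 therefore stands at the limit of > 60000 nM in this assay, at which 2 of the 3 values shown sit, with no number of its own. Compound 4 `CS(=O)(=O)c1ccc(C(=O)NCCCC(=O)N2CCCCC2)cc1[N+](=O)[O-]` has not yet been measured in this assay. It differs from compound 1 by a group of 6 heavy atoms (5 carbon, 1 nitrogen; one six-membered non-aromatic ring with 1 hetero atom) in place of a group of 9 heavy atoms (8 carbon, 1 nitrogen; one five-membered non-aromatic ring with 1 hetero atom, one six-membered aromatic ring of carbon only), on a carbonyl carbon. Going by the values given here, no pair of measured compounds differs in a single place, so the size of this change cannot be read from the data. Compound 4 is expected to give about 60000 nM, somewhere between 25000 nM and 150000 nM. The step implied by this estimate, a number no higher from compound 1 to compound 4 (the limit leaves the size open), is expected to be none beyond the scatter, most likely leaving compound 4 at a limit as well.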

Compound 4, half-maximal inhibitory concentration: > 60000 nM
Compound 4 ended at the assay's limit (the forecaster's own chance of this, stated with the estimate: 80%); the middle value lies on the limit itself.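

Compound 1 and compound 4 both end at a limit rather than a number, so no step between them can be read: the limit of > 60000 nM in this assay, at which 3 of the 4 values shown sit.

The compounds shown leave open whether piperidin-1-yl on the carbonyl carbon changes inhibition at all.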